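Thiophene in place of a methylphenyl on the amide carbonyl

This account rests on a few compounds, and the source may have more. Where it says the series, first, only, none or still open, it means among the compounds named here.

Going by the values given here, compound 1 `Cc1ccccc1C(=O)Nc1c(C(O)(C(F)(F)F)C(F)(F)F)ccc2ccccc12` stands highest of the two numbers so far in an assay on LtK cells with ATP-sensitive inward rectifier potassium channel 11 (Homo sapiens) as the target (on this read-out higher numbers stand for an effect only at larger amounts of compound and lower numbers for an effect already at smaller amounts), where compound 1 gives 5550 nM. Among the compounds with values here, its nearest neighbour is compound 2 `O=C(Nc1c(C(O)(C(F)(F)F)C(F)(F)F)ccc2ccccc12)c1ccc(I)cc1`, which in this assay gives 154 nM; the only measured step, a 36-fold lower number from compound 1 to compound 2 (1.56 log units; beyond the scatter), came with 4-iodophenyl in place of 2-methylphenyl on a carbonyl carbon. Compound 3 `O=C(Nc1c(C(O)(C(F)(F)F)C(F)(F)F)ccc2ccccc12)c1cccs1` carries a different change at the same place: thiophen-2-yl in place of 2-methylphenyl on a carbonyl carbon. Within the data shown here, no measured step shows this exact exchange, so the one known step bears on it only loosely, through the observation that leaving the 2-methylphenyl of compound 1 gave a large drop in number. A smaller drop is therefore expected for compound 3, namely a 3.7-fold lower number from compound 1 to compound 3 (0.57 log units; beyond the scatter). Compound 3 is estimated at 1500 nM in this assay, within a range from 300 nM to 7000 nM.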

Compound 3, half-maximal effective concentration: 12 nM
Compound 3: the middle estimate sits 130-fold (2.10 log units) above what was measured; the whole stated range lies above it.
By their numbers in this assay, from the lowest: compound 3; then compound 2; then compound 1.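

In this assay, the thiophen-2-yl group on the carbonyl carbon gives the lowest number of the three compounds, with a 460-fold lower number from compound 1 to compound 3 (2.67 log units; beyond the scatter). A six-membered aromatic ring of carbon only is therefore not required at this position for a low number, and a 13-fold lower number from compound 2 to compound 3 (1.11 log units; beyond the scatter) shows that the number seen with 4-iodophenyl was not the lowest reachable here. Nothing available explains why this exchange has so large an effect.

The compounds shown leave open whether the low number follows the sulfur, the five-membered ring or the point of attachment, since all three arrive together in compound 3; furan-2-yl and thiophen-3-yl groups on the same carbonyl carbon would help to separate them. They also leave open how an unsubstituted phenyl group would compare with the 2-methylphenyl of compound 1.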